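The source may hold more compounds than are shown below. What is called first, only, known or untested is meant among the compounds shown, and "the series" means these compounds.

Series notes. Compound 1 `CN1CCC[C@H]1[C@@H]1COc2ccc(N)cc2O1` and compound 2 `CN1CCC[C@H]1[C@@H]1COc2cc(N)ccc2O1` are built from the same atoms joined differently; the difference between the two cores is not broken down here. In an assay on membranes from HEK293 cells for displacement of a labelled ligand from Neuronal acetylcholine receptor; alpha3/beta4 (Homo sapiens), with a stated time of 5 min (on this read-out lower numbers stand for stronger inhibition and higher numbers for weaker inhibition), compound 1 gives 19 nM, while compound 2 gives 3500 nM. Compound 3 `CN1CCC[C@H]1[C@@H]1COc2ccc([N+](=O)[O-])cc2O1` carries nitro in place of amino on an aromatic carbon and in this assay compound 3 gives 4500 nM; the step is a 240-fold higher number from compound 1 to compound 3 (2.37 log units; beyond the scatter). Compound 2 and compound 3 lie within the scatter of each other.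

Compound 4 `CN1CCC[C@H]1[C@@H]1COc2cc([N+](=O)[O-])ccc2O1` is not yet measured. It differs from compound 2 by nitro in place of amino on an aromatic carbon, and the place is described in the same words as for the change from compound 1 to compound 3, so this is the same change made on the other core. In this assay the step from compound 2 to compound 4 is expected to be a 7.1-fold higher number from compound 2 to compound 4 (0.85 log units; beyond the scatter), smaller than a 240-fold higher number from compound 1 to compound 3 (2.37 log units; beyond the scatter), because compound 2 already stands at 3500 nM and a step of the earlier size would run far past the weak end of the series. For compound 4 the estimate is 25000 nM, with a range from 5000 nM to 150000 nM, and the assay may return only a limit.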

Compound 4, inhibition constant: 15000 nM
Compound 4: the middle estimate sits 1.7-fold (0.22 log units) above what was measured; low and high end bracket the measured number.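

The change from amino to nitro gives a higher number on both cores in this assay, and on the core of compound 2 it gives a 4.3-fold higher number from compound 2 to compound 4 (0.63 log units; beyond the scatter). The direction carries across the two cores, but the size of the step does not: the same change on two cores in this assay, a 240-fold higher number (2.37 log units; beyond the scatter) from compound 1 to compound 3 and a 4.3-fold higher number (0.63 log units; beyond the scatter) from compound 2 to compound 4, 55-fold (1.74 log units) apart, beyond the scatter of two such steps These two pairs do not show why the steps differ in size, and they give no rule for how the change would read on any further core.

The compounds shown hold only amino and nitro at this place on the two cores, so it remains open whether the low number of compound 1 is specific to amino or would be shared by a hydroxyl group, a methylamino group or an acetamide. Going by these compounds, it also remains open whether a group of this kind would give steps as far apart on the two cores as amino and nitro do, since a single pair per core cannot separate the group from the core.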